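The source may report more compounds than this note shows. Statements on the series, on what has been measured and on what is new or still open speak of the compounds shown alone.

Measured compounds in a functional assay on HeLa cells (Homo sapiens) for cytotoxicity, read by MTT assay, with a stated time of 48 h; on this read-out higher numbers stand for weaker inhibition and lower numbers for stronger inhibition:
compound 1 `O=c1ccoc2cc(OCc3cn(Cc4cccc(F)c4)nn3)ccc12`, with 7550 nM
compound 2 `CC(C)(C)c1ccc(Cn2cc(COc3ccc4c(=O)ccoc4c3)nn2)cc1`, with 17600 nM

Of the two numbers in hand, compound 1 gives the lower one; compound 2 sits higher by a step that lies beyond the usual scatter of repeated measurements. Compound 3 `N#Cc1cccc(Cn2cc(COc3ccc4c(=O)ccoc4c3)nn2)c1` has not yet been measured in this assay. It is obtained from compound 1 by one change, (cyano in place of fluoro on an aromatic carbon). Going by the values given here, no measured pair shows what this exchange does in this assay, and the two measured compounds differ from each other at a different place, so the data give no direction for it. The step is therefore expected to stay within the scatter, an estimated 1.1-fold higher number from compound 1 to compound 3 (0.03 log units; within the scatter). Compound 3 is accordingly expected to give about 8000 nM in this assay, with a likely range from 3000 nM to 22000 nM.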

Compound 3, half-maximal inhibitory concentration: > 100000 nM
Compound 3 ended at the assay's limit; the forecaster's own chance of this, stated with the estimate: 10%; middle value at least 12-fold (1.09 log units) away from the limit.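

In this assay, cyano in place of fluoro on an aromatic carbon, meta to a large group, gives an at least 13-fold higher number from compound 1 to compound 3 (1.12 log units; beyond the scatter), a step beyond the usual scatter. Compound 3 gives > 100000 nM, which is a limit of the assay and not a number. This place on the aromatic ring is therefore not indifferent to the group it carries, since 3-fluorobenzyl to 3-cyanobenzyl alone is enough to reach that limit, and the step gives only a lower bound on the change: the limit of > 100000 nM in this assay, at which 1 of the 3 values shown sits.

The compounds shown do not tell whether fluoro is specifically favourable at this place or cyano specifically unfavourable. As far as these compounds go, what plain hydrogen, chloro, methoxy or an amine would give here remains open, as does whether the same exchange would have a similar effect at another place on the ring.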